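A few compounds are considered here, and "the series" means these few. Any claim that something is new, unique, unknown or untested is made for them only; others in the source may bear on it.

In a functional assay on Raji cells (Homo sapiens) for cytotoxicity, with a stated time of 72 h (a lower number here means that less compound is needed, a higher number that more compound is needed for the effect), compound 1 (`C=C[C@@](C)(/C=C/c1ccc(O)cc1)CC/C=C(C)/C=C/C(=O)OCC`) reads > 26000 nM as a limit of the assay, not a number. Among the measured compounds shown here, compound 2 (`COc1ccc(/C=C/[C@@](C)(/C=C/c2ccc(O)c(C=O)c2)CCC=C(C)C)cc1`) gives 13000 nM as the only actual number so far. Compound 3 (`COc1ccc(/C=C/[C@@](C)(/C=C/c2ccc(O)c(/C=C/C(=O)OCc3ccccc3)c2)CCC=C(C)C)cc1`) differs from compound 2 by having 2-(benzyloxycarbonyl)ethenyl in place of formyl on an aromatic carbon, ortho to a hydroxy group (2-(benzyloxycarbonyl)ethenyl in place of formyl on an aromatic carbon). For the measured compounds named here, no measured step sizes such a change, so no shift beyond the scatter is expected in this assay and the uncertainty is wide. The expected step of a 1.3-fold lower number from compound 2 to compound 3 (0.11 log units; within the scatter) is small. Compound 3 is estimated at 10000 nM with an expected range from 3000 nM to 26000 nM in this estimate.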

Compound 3, half-maximal effective concentration: > 26000 nM
Compound 3: no number, only a limit; the forecaster's own chance of this, stated with the estimate: 30%; middle value at least 2.6-fold (0.41 log units) away from the limit.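

In this assay, the aromatic carbon ortho to a hydroxy group now has its first sized change: 2-(benzyloxycarbonyl)ethenyl in place of formyl gives an at least 2.0-fold higher number from compound 2 to compound 3 (0.30 log units; that floor lies within the scatter). Compound 3 stands at a limit of the assay, not a number, so this step is only a floor. Among the compounds shown here, compound 2 therefore remains the only actual number, and the limit now bounds most of what the series can show: the limit of > 26000 nM in this assay, at which 2 of the 3 values shown sit.

As far as these compounds go, the true size of the step stays open. Also open, from the compounds shown here alone, is how a carboxylic acid or an amine on this aromatic carbon would read in this assay.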